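The source may report more compounds than this note shows. Statements on the series, on what has been measured and on what is new or still open speak of the compounds shown alone.

Measured so far in an ADME assay on A549 cells (Homo sapiens) for cytotoxicity, read by CellTiter-Glo; a lower number here means that less compound is tolerated, a higher number that more compound is tolerated:
Compound 1 `Cc1c(Cc2ccccc2)c(=O)oc2cc(OCC(O)CNC3CCOCC3)ccc12` gives 38200 nM.
Compound 2 `Cc1c(Cc2ccccc2)c(=O)oc2cc(OCC(O)CNCc3cccs3)ccc12` gives 87300 nM.

Among these two numbers, compound 2 stands at the higher end, and the only measured step, a 2.3-fold higher number from compound 1 to compound 2 (0.36 log units; beyond the scatter), separates it from compound 1. Compound 3 `Cc1c(Cc2ccccc2)c(=O)oc2cc(OCC(O)CNc3nc4ccccc4[nH]3)ccc12` has not yet been measured in this assay. It differs from compound 2 by 1H-benzimidazol-2-yl in place of (thiophen-2-yl)methyl on an amine nitrogen. Among the measured compounds shown here, only one measured step bears on this change, a 2.3-fold higher number from compound 1 to compound 2 (0.36 log units; beyond the scatter), and it concerns a different group at the same amine nitrogen, so it shows how far a swap at this position has moved the number but gives no direction for the benzimidazolyl group. Compound 3 is therefore expected to stay close to compound 2, with a step of a 1.5-fold lower number from compound 2 to compound 3 (0.16 log units; within the scatter), a shift that is not expected to go clearly beyond the scatter. For compound 3 the estimate in this assay is 60000 nM, within a range from 20000 nM to 180000 nM.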

Compound 3, half-maximal cytotoxic concentration: > 100000 nM
Compound 3: only a limit was reported (the forecaster's own chance of this, stated with the estimate: 15%); middle value at least 1.6-fold (0.22 log units) away from the limit.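

In this assay compound 3 gives > 100000 nM, which is a limit of the assay and not a number: the limit of > 100000 nM in this assay, at which 1 of the 3 values shown sits. Even so, the reading shows that this amine nitrogen can carry 1H-benzimidazol-2-yl, with its aromatic ring attached directly, and against oxan-4-yl the limit still gives an at least 2.6-fold higher number from compound 1 to compound 3 (0.41 log units; beyond the scatter). Against (thiophen-2-yl)methyl the limit gives only an at least 1.1-fold higher number from compound 2 to compound 3 (0.05 log units; that floor lies within the scatter), a floor within the scatter, so it does not establish that the new group lies higher than the thiophene-bearing one.

From the compounds shown here alone, the true value of compound 3 remains unknown, so the size of both steps is open at the upper end. Also open, going by these compounds, is whether a benzyl group or a 1H-imidazol-2-yl group on the same amine nitrogen would read like either of these groups.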